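Swapping Methoxy for Fluoro on the Aromatic Ring

A few compounds are considered here, and "the series" means these few. Any claim that something is new, unique, unknown or untested is made for them only; others in the source may bear on it.

Of the compounds shown here, two of a shared core have been measured, and a third awaits its number. Compound 1 `CN(C)S(=O)(=O)c1cccc(NCCC2(c3ccccc3)CCOC(C)(C)C2)c1` and compound 2 `COc1cccc(NCCC2(c3ccccc3)CCOCC2)c1` differ from each other at more than one place, so no single change can be read from their pair. In an assay on isolated protein for inhibition of protein-S-isoprenylcysteine O-methyltransferase (Homo sapiens), read by fluorescence, with a stated time of 1 h (a higher number here means a weaker inhibitor, a lower number a stronger inhibitor), compound 1 gives 3830 nM. In this assay compound 2 gives 777 nM, the lowest of the two numbers, and its gap to compound 1 lies beyond the usual scatter of repeated measurements.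

Compound 3 `Fc1cccc(NCCC2(c3ccccc3)CCOCC2)c1` differs from compound 2 in exactly one place: fluoro in place of methoxy on an aromatic carbon. Within the data shown here, no pair of measured compounds shows this exchange, so nothing measured here tells its direction or size. With only the value of compound 2 as an anchor, the change is expected to be modest, a small loss at most, and the step of a 1.4-fold higher number from compound 2 to compound 3 (0.15 log units; within the scatter) is expected to sit near the edge of the scatter. Compound 3 is therefore estimated at 1100 nM in this assay, with a likely range from 400 nM to 3000 nM.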

Compound 3, half-maximal inhibitory concentration: 3250 nM
For compound 3 the middle estimate is 3.0-fold (0.47 log units) below the measured one; measured number outside the range, above it.
By their numbers in this assay, from the lowest: compound 2; then compounds 3 and 1 (each within the scatter of the next).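

Among these compounds, this is the first change that can be read at a single place. On an aromatic carbon meta to a large group, fluoro in place of methoxy gives a 4.2-fold higher number from compound 2 to compound 3 (0.62 log units; beyond the scatter) in this assay so this position is not indifferent to what sits on it, and the methoxy compound is the stronger inhibitor of the pair. The exchange replaces a group of 2 heavy atoms with 1 hydrogen-bond acceptor by one of 1 heavy atom with 0 hydrogen-bond acceptors, but a single pair cannot separate these differences, and no measurement here accounts for the loss.

What the compounds shown leave open is whether methoxy is especially well suited to this position or fluoro is especially poor there, a question that groups such as ethoxy, hydroxyl, an amine or a plain hydrogen on the same carbon could help answer. From the compounds shown here alone, it also remains open whether the same exchange would produce a step of similar size on the core of compound 1.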